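Methoxy for Chloro: Expecting the Next Cytotoxicity Number

This account rests on a few compounds, and the source may have more. Where it says the series, first, only, none or still open, it means among the compounds named here.

Compound 1 `Cc1[nH]c2ccccc2c1C(c1ccccc1)c1cc2cc(Cl)ccc2o1` and compound 2 `COc1ccc2oc(C(c3ccccc3)c3c(C)[nH]c4ccccc34)cc2c1` differ in a single place: methoxy in place of chloro on an aromatic carbon. In a functional assay on SiHa cells (Homo sapiens) for cytotoxicity (on this read-out higher numbers stand for weaker inhibition and lower numbers for stronger inhibition), compound 1 gives 47500 nM. For compound 2 the outcome in this assay is only a limit of the assay, > 100000 nM. The step of an at least 2.1-fold higher number from compound 1 to compound 2 (0.32 log units; beyond the scatter) therefore runs into (the limit of > 100000 nM in this assay, at which 1 of the 3 values shown sits). Compound 3 `CC(C)(C)c1cc(C(C)(C)C)c2oc(C(c3ccc(Cl)cc3)c3c[nH]c4ccc([N+](=O)[O-])cc34)cc2c1` rests on a core whose difference from that of compound 1 is not broken down here; in this assay compound 3 gives 36900 nM, which lies within the scatter of compound 1. Compound 4 `COc1ccc(C(c2cc3cc(C(C)(C)C)cc(C(C)(C)C)c3o2)c2c[nH]c3ccc([N+](=O)[O-])cc23)cc1` carries the same kind of change, (methoxy in place of chloro on an aromatic carbon), here para to a large group rather than meta to a fused ring and para to a fused ring within a fused system. Leaning on the step of an at least 2.1-fold higher number from compound 1 to compound 2 (0.32 log units; beyond the scatter), compound 4 is expected to shift by a 2.2-fold higher number from compound 3 to compound 4 (0.34 log units; beyond the scatter) in this assay. Compound 4 is thus estimated at 80000 nM, most likely between 30000 nM and 200000 nM.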

Compound 4, half-maximal inhibitory concentration: > 100000 nM
Compound 4 ended at the assay's limit; the forecaster's own chance of this, stated with the estimate: 40%; at least 1.2-fold (0.09 log units) between middle value and limit.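

In this assay compound 4 gives > 100000 nM, which is a limit of the assay and not a number. The step, an at least 2.7-fold higher number from compound 3 to compound 4 (0.43 log units; beyond the scatter), is thus open-ended, and it stands beside the earlier one: the same change on two cores in this assay, an at least 2.1-fold higher number (0.32 log units; beyond the scatter) from compound 1 to compound 2 and an at least 2.7-fold higher number (0.43 log units; beyond the scatter) from compound 3 to compound 4; the limit leaves it open whether they differ. Methoxy in place of chloro therefore moves the number the same way on both cores, beyond the scatter each time, but this does not show how large the change is on either core or whether the two sizes match: the limit of > 100000 nM in this assay, at which 2 of the 4 values shown sit.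

Only chloro and methoxy stand at these places among the compounds shown. On these data alone, how an amine or a carboxylic acid there would read in this assay stays open.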